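The source may report more compounds than this note shows. Statements on the series, on what has been measured and on what is new or still open speak of the compounds shown alone.

Measured compounds:
compound 1 `COc1ccc(Nc2ccc3c(c2)C(=O)N(C2CCC(=O)NC2=O)C3=O)cc1` — 29%
compound 2 `O=C1CCC(N2C(=O)c3cccc(Nc4ccccn4)c3C2=O)C(=O)N1` — 1%

Of the compounds shown here, two have numbers so far. In an assay on FRT-Jurkat cells for inhibition of nuclear factor NF-kappa-B complex (Homo sapiens), read by flow cytometry, with a stated time of 24 h, tested at 10 uM (a higher number here means more inhibition at the concentration tested (going by the name of the read-out), a lower number less inhibition), compound 1 gives 29%, and compound 2 gives 1%. Compound 1 therefore stands as the higher of the two, and the gap between compound 1 and compound 2 lies beyond the usual scatter. Among the compounds with values here, no pair of measured compounds differs in a single place, so no measured step is available to set a scale for small changes.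

Compound 3 `CCCc1ccc(Nc2ccc3c(c2)C(=O)N(C2CCC(=O)NC2=O)C3=O)cc1` is the next compound for this assay. Relative to compound 1 the change is propyl in place of methoxy on an aromatic carbon. Within the data shown here, with no measured step of this kind to lean on, the step from the value of compound 1 is expected to be small, in either direction, and not beyond the scatter. The expected step is a number 4 percentage points lower from compound 1 to compound 3 (within the scatter). Compound 3 is thus estimated at 25%, with a range from 5% to 45%.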

Compound 3, a percentage reported as inhibition, at one concentration (the size of the read-out at that concentration, not a potency): 10%
Estimate against measurement, compound 3: 15 percentage points above; the measured number falls inside the stated range.
By their numbers in this assay, from the lowest: compounds 2 and 3 (each within the scatter of the next); then compound 1.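

In this assay, within the data shown here, going from 4-methoxyphenyl to 4-propylphenyl gives a number 19 percentage points lower from compound 1 to compound 3 (beyond the scatter), the only measured step that differs in one place. It shows that a change on this aromatic carbon, para to a large group, can move the read-out beyond the scatter, so the position is not indifferent to the group it carries. No measurement at hand bears on why the step occurs.

This single pair cannot separate the loss of the oxygen, with its hydrogen-bond acceptor, from the gain of the propyl chain; an ethoxy or a butyl group at the same place would help to pull the two apart. It also leaves open whether an amine or a carboxylic acid there would take the read-out past compound 1 at 29%.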